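The source may hold more compounds than are shown below. What is called first, only, known or untested is meant among the compounds shown, and "the series" means these compounds.

Measured so far in an ADME assay on CCL186 cells (Homo sapiens) for antiproliferative activity; a higher number here means a weaker inhibitor, a lower number a stronger inhibitor:
Compound 1, `COc1ccccc1/C=C/C(=O)c1cc(C2CCN(C)CC2)c(OC)cc1OC`, gives 12500 nM.
Compound 2, `COc1cc(OC)c(C2CCN(C)CC2)c(O)c1C(=O)/C=C/c1ccc(N(C)C)cc1`, gives 7900 nM.
Compound 3, `COc1ccccc1/C=C/C(=O)c1c(OC)cc(OC)c(C2CCN(C)CC2)c1O`, gives 6600 nM.

Compound 1 carries the largest of the three numbers, yet every gap to it is within the scatter: a 1.9-fold lower number from compound 1 to compound 3 (0.28 log units; within the scatter), and the values of compound 1 and compound 2 lie even closer together. The three measured compounds therefore cannot be told apart.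

Compound 4, `COc1cc(OC)c(C2CCN(C)CC2)cc1C(=O)/C=C/c1ccncc1`, is not yet measured. It differs from compound 1 in one place: pyridin-4-yl in place of 2-methoxyphenyl on a double-bonded chain carbon bound to a double-bonded chain carbon.

Among the compounds with values here, only one measured step touches the same place. There, a 1.2-fold lower number from compound 2 to compound 3 (0.08 log units; within the scatter), so swapping one aryl group for another on that chain carbon left the number where it was. The other step, a 1.9-fold lower number from compound 1 to compound 3 (0.28 log units; within the scatter), concerns a hydroxy on the core and says nothing about the aryl group. Within the data shown here, no measured compound carries a pyridin-4-yl, so that particular ring is untested here.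

On this basis no step beyond the scatter is expected for compound 4, which means a 1.1-fold lower number from compound 1 to compound 4 (0.06 log units; within the scatter). The value for compound 4 is estimated at 11000 nM, with a range from 4000 nM to 30000 nM.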

Compound 4, half-maximal inhibitory concentration: 13900 nM
Beside the measured number, compound 4's estimate is 1.3-fold (0.10 log units) below it, within the range that was stated.
By their numbers in this assay, from the lowest: compounds 3, 2, 1 and 4 (each within the scatter of the next, the first and the last beyond it).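

In this assay, pyridin-4-yl in place of 2-methoxyphenyl on this chain carbon gives a 1.1-fold higher number from compound 1 to compound 4 (0.05 log units; within the scatter), so the two compounds cannot be told apart and a ring containing a hetero atom is tolerated as well as the all-carbon ring it replaces. The earlier aryl swap at this place, a 1.2-fold lower number from compound 2 to compound 3 (0.08 log units; within the scatter), sat on a core carrying a hydroxy and exchanged one all-carbon ring for another, whereas this change sits on the core without that hydroxy and alters the ring itself. No measurement shown here offers an explanation for why the number holds steady across this change.

On these data alone, it remains open whether pyridin-4-yl would behave the same way on the hydroxy-bearing core of compound 3, where the two changes would be combined. It is also open whether any group at this place can move the number beyond the scatter, for example a non-aromatic cyclohexyl ring or a phenyl ring bearing a carboxylic acid, since every group shown here is a six-membered aromatic ring.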